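The source may hold more compounds than are shown below. What is called first, only, known or untested is meant among the compounds shown, and "the series" means these compounds.

Three compounds have been measured in a functional assay (aorta) with Oryctolagus cuniculus as the target; on this read-out lower numbers stand for stronger inhibition and higher numbers for weaker inhibition:

Compound 1, `OCc1ccc(-c2nn(Cc3ccc(Cl)s3)c3ccccc23)o1`: 7200 nM
Compound 2, `OCc1ccc(-c2nn(Cc3ccccc3F)c3ncncc23)o1`: 9400 nM
Compound 3, `CCc1cnc(-c2nn(Cc3ccccc3F)c3ncccc23)nc1N`: 272000 nM

Compound 3 stands at the highest of the three numbers in this assay. Its nearest neighbour is compound 2, whose number is lower by a gap that lies beyond the scatter, and compound 1 lies lower still, also beyond the scatter. Compound 3 is therefore the weakest inhibitor among the three measured compounds.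

Compound 4, `CC(C)S(=O)(=O)c1cnc(-c2nn(Cc3ccccc3F)c3ncccc23)nc1N`, differs from compound 3 in a single place: isopropylsulfonyl in place of ethyl on an aromatic carbon. Among the compounds with values here, no pair of measured compounds shows this change, so its effect in this assay is untested. The three measured compounds differ from one another in several places at once, and none of them shares the core of compound 3 with another group at this position. The writer therefore expects the step of a 1.8-fold lower number from compound 3 to compound 4 (0.26 log units; within the scatter) to be modest, most likely within the scatter or a little beyond it, with the direction uncertain. Compound 4 is estimated at 150000 nM in this assay, within a range from 30000 nM to 600000 nM.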

Compound 4, half-maximal inhibitory concentration: 517000 nM
Compound 4: middle estimate off by 3.4-fold (0.54 log units), on the low side, and the stated range covers the measured number.
By their numbers in this assay, from the lowest: compounds 1 and 2 (each within the scatter of the next); then compounds 3 and 4 (each within the scatter of the next).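

Within the data shown here, putting isopropylsulfonyl in place of ethyl on this aromatic carbon, ortho to an amino group and two atoms from the ring nitrogen, gives in this assay a step that stays within the scatter (a 1.9-fold higher number from compound 3 to compound 4 (0.28 log units; within the scatter)), so this pair offers the first direct reading of a change at this position. The position carries the entering group, with 6 heavy atoms and 2 hydrogen-bond acceptors against 2 heavy atoms and 0 hydrogen-bond acceptors for ethyl, and the read-out does not separate compound 3 from compound 4. No measurement is available that would explain this outcome.

The compounds shown leave open whether a primary amine, a carboxylic acid, a methylsulfonyl group or a plain hydrogen on this aromatic carbon would move the number beyond the scatter, in either direction. They also leave open whether isopropylsulfonyl and ethyl would read as closely on a different core as they do on the core of compound 3.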